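Swapping an Amine Arm on a Cytotoxicity-Clean Scaffold

The compounds below may be only part of what the source reports. "The series", "measured", "known", "first", "only" and "open" are said of these compounds alone.

Compound 2 `CCCN(CCC)c1cc2[nH]c(C3CCCCC3)nc2cc1NC(=O)c1ccccc1` was tested in an ADME assay on Vero cells (Chlorocebus sabaeus) for cytotoxicity, read by resazurin assay, with a stated time of 3 days; on this read-out higher numbers stand for weaker inhibition and lower numbers for stronger inhibition. In this assay compound 2 gives > 100 ug/mL, which is a limit of the assay rather than a measured number. Among the compounds with values here, the other two compounds tested so far tell the same story. Compound 1 `CCCNC(=O)Nc1cc2nc(C3CCCCC3)[nH]c2cc1N1CCCC1` gives > 100 ug/mL in this assay, again a limit. Compound 3 `CCCN(CCC)c1cc2[nH]c(C3CCCCC3)nc2cc1NC(=O)OCc1ccccc1` gives > 100 ug/mL in this assay, also a limit. Within the data shown here, because the limit of > 100 ug/mL in this assay, at which 3 of the 3 values shown sit, every value so far sits at the same edge, the step that the two limits leave unreadable from compound 2 to compound 3 cannot be read: exchanging one group for another on a carbonyl carbon left both compounds beyond the range the assay reports.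

The new compound 4 `O=C(Nc1cc2nc(C3CCCCC3)[nH]c2cc1N1CCCC1)c1ccccc1` is made from compound 2 by a single change: pyrrolidin-1-yl in place of dipropylamino on an aromatic carbon. Compound 1 already carries a pyrrolidin-1-yl group on the shared core and sits at the limit, so this piece of the structure has not by itself brought a value into the readable range. With no readable step in either direction, no shift beyond the scatter is expected. Compound 4 is therefore expected to give 150 ug/mL in this assay, with a likely range from 80 ug/mL to 400 ug/mL. The estimated step that the limit leaves unreadable from compound 2 to compound 4 is expected to be flat, and the assay will most probably again report only a limit.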

Compound 4, half-maximal inhibitory concentration: > 100 ug/mL
Compound 4 was reported as a limit; the forecaster's own chance of this, stated with the estimate: 85%; the middle value does not contradict the limit.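

In this assay compound 4 gives > 100 ug/mL, which is a limit of the assay. The steps from compound 1 and from compound 2 to compound 4 therefore cannot be read: the limit of > 100 ug/mL in this assay, at which 4 of the 4 values shown sit. The compounds shown leave open how far past this limit each compound lies, and whether any change on the shared core would give a readable value.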